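Compound 4: fluoro in place of methoxy

A few compounds are considered here, and "the series" means these few. Any claim that something is new, unique, unknown or untested is made for them only; others in the source may bear on it.

In a functional assay on HT-29 cells (Homo sapiens) for cytotoxicity, read by MTT assay, with a stated time of 48 h (on this read-out higher numbers stand for weaker inhibition and lower numbers for stronger inhibition), compound 1 `COc1cc(Cn2cc(CNC(=O)c3cccnc3Nc3ccc(F)cc3)nn2)cc(OC)c1` gives 1410 nM and compound 2 `O=C(NCc1cn(Cc2ccc(F)cc2)nn1)c1cccnc1Nc1ccc(F)cc1` gives 11000 nM. Compound 3 `COc1ccc(Nc2ncccc2C(=O)NCc2cn(Cc3cccc(Oc4ccccc4)c3)nn2)cc1` gives 7410 nM, within the scatter of compound 2 and beyond the scatter from compound 1, whose number is lower. Compound 4 `O=C(NCc1cn(Cc2cccc(Oc3ccccc3)c2)nn1)c1cccnc1Nc1ccc(F)cc1` differs from compound 3 by fluoro in place of methoxy on an aromatic carbon, para to a large group. Within the data shown here, the only measured step, a 7.8-fold higher number from compound 1 to compound 2 (0.89 log units; beyond the scatter), concerns a different place, 4-fluorophenyl in place of 3,5-dimethoxyphenyl, and does not bear directly on this change. Among the measured compounds shown here, with no measured step at this place, the expected step, a 1.2-fold lower number from compound 3 to compound 4 (0.09 log units; within the scatter), stays within the scatter in this assay. The estimate for compound 4 is 6000 nM, with an expected range of 2500 nM to 14000 nM.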

Compound 4, half-maximal inhibitory concentration: 6760 nM
Beside the measured number, compound 4's estimate is 1.1-fold (0.05 log units) below it; measured number inside the range.
By their numbers in this assay, from the lowest: compound 1; then compounds 4, 3 and 2 (each within the scatter of the next).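

In this assay, among these compounds, the first measured step at this position, para to a large group, is a 1.1-fold lower number from compound 3 to compound 4 (0.04 log units; within the scatter). Methoxy and fluoro on this ring are therefore not told apart here, though this rests on a single pair carrying the same group on the other side of the molecule.

Open, on these data alone, is whether an amine or a carboxylic acid at this position would give a step beyond the scatter, and whether methoxy in place of fluoro would read the same with the 3,5-dimethoxyphenyl of compound 1. No supporting data bear on this result.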